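Fluoro in place of methyl on compound 2

This account rests on a few compounds, and the source may have more. Where it says the series, first, only, none or still open, it means among the compounds named here.

Compound 1 `O=S(=O)(c1ccc(F)cc1)c1nc2ccccc2nc1N1CCCC1`: 30100 nM
Compound 2 `Cc1ccc(S(=O)(=O)c2nc3ccccc3nc2N2CCC(O)CC2)cc1`: 6140 nM

In a functional assay on KB cells (Homo sapiens) for cytotoxicity, read by MTT assay, with a stated time of 72 h (on this read-out lower numbers stand for stronger inhibition and higher numbers for weaker inhibition), compound 2 gives 6140 nM, the lower of the two numbers, and its gap to compound 1 lies beyond the scatter. The next compound is compound 3 `O=S(=O)(c1ccc(F)cc1)c1nc2ccccc2nc1N1CCC(O)CC1`, reached from compound 2 through fluoro in place of methyl on an aromatic carbon, para to a large group. Among the measured compounds shown here, no measured pair differs in one place only, so this change has no direct precedent here. Compound 1 also carries the 4-fluorophenyl, but it differs from compound 2 in a second place, so the value of compound 1 at 30100 nM cannot be credited to that group alone. The expected change is small, a slight rise in the number and none beyond the scatter, as the estimated 1.3-fold higher number from compound 2 to compound 3 (0.11 log units; within the scatter) shows. For compound 3 the expected value is 8000 nM, with an estimated range of 2500 nM to 25000 nM.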

Compound 3, half-maximal inhibitory concentration: 9580 nM
Beside the measured number, compound 3's estimate is 1.2-fold (0.08 log units) below it; the range from low to high includes it.
By their numbers in this assay, from the lowest: compounds 2 and 3 (each within the scatter of the next); then compound 1.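

In this assay the change from 4-methylphenyl to 4-fluorophenyl gives a 1.6-fold higher number from compound 2 to compound 3 (0.19 log units; within the scatter) with the 4-hydroxypiperidin-1-yl group held fixed, so the two groups are not separated at this position. Among the compounds shown here, compound 3 also provides the first comparison at the other varied place: with the 4-fluorophenyl held fixed, 4-hydroxypiperidin-1-yl in place of pyrrolidin-1-yl gives a 3.1-fold lower number from compound 1 to compound 3 (0.50 log units; beyond the scatter) and this modest step is the only one here beyond the scatter. No measurement shown accounts for either step. That ring exchange alters both ring size and the hydroxyl, and an unsubstituted piperidin-1-yl group would be needed to separate the two. Going by these compounds, it also remains open whether a chloro or methoxy group on the phenyl ring would move the number any further than fluoro or methyl.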